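A few compounds are considered here, and "the series" means these few. Any claim that something is new, unique, unknown or untested is made for them only; others in the source may bear on it.

Within the data shown here, compound 2 `CC(C)c1ccccc1N1CCC(C(=O)Nc2ccc3c(c2)NC(=O)CO3)CC1` gives 180 nM in a functional assay for antagonist activity at transient receptor potential cation channel subfamily V member 1 (Homo sapiens), read by FLIPR and calcium flux (a higher number here means a weaker inhibitor, a lower number a stronger inhibitor), the lowest of the three numbers measured so far. Compound 1 `Cc1cccc(N2CCC(C(=O)Nc3ccc4c(c3)NC(=O)CO4)CC2)c1` gives 490 nM in this assay, and compound 3 `COC(=O)CC1Oc2ccc(NC(=O)C3CCN(c4cc(F)cc(F)c4)CC3)cc2NC1=O` gives 890 nM in this assay; both of their gaps to compound 2 lie beyond the scatter. Among the measured compounds shown here, the only single-point step measured is a 2.7-fold lower number from compound 1 to compound 2 (0.43 log units; beyond the scatter), and it is the one step that bears on the aryl group carried by the amine nitrogen in the ring. Compound 4 `O=C1COc2ccc(NC(=O)C3CCN(c4ccccc4C(F)(F)F)CC3)cc2N1` is not yet measured; it differs from compound 2 by trifluoromethyl in place of isopropyl on an aromatic carbon. For the measured compounds named here, no measured step covers a swap of this kind on that aryl ring, so the change from compound 1 to compound 2 serves only as a rough guide to how far this part of the molecule moves the number. A step within the scatter, or at most a modest one in either direction, is expected, and compound 4 is estimated at 250 nM (range 100 nM to 600 nM), which would mean a 1.4-fold higher number from compound 2 to compound 4 (0.14 log units; within the scatter).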

Compound 4, half-maximal inhibitory concentration: 380 nM
Compound 4: middle estimate off by 1.5-fold (0.18 log units), on the low side, within the range that was stated.
By their numbers in this assay, from the lowest: compound 2; then compounds 4, 1 and 3 (each within the scatter of the next, the first and the last beyond it).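

In this assay, the place on the aromatic carbon ortho to a large group tells apart two groups of similar heavy-atom count: trifluoromethyl in place of isopropyl gives a step beyond the scatter (a 2.1-fold higher number from compound 2 to compound 4 (0.32 log units; beyond the scatter)). The lower number of compound 2 therefore does not carry over to every group at this place, and 2-(trifluoromethyl)phenyl cannot be separated from 3-methylphenyl (a 1.3-fold lower number from compound 1 to compound 4 (0.11 log units; within the scatter)). Nothing at hand gives a measured reason for the difference between isopropyl and trifluoromethyl.

Still open, on these data alone, is how a tert-butyl, methoxy or nitrile group would read at this same place, and whether isopropyl holds its number when moved elsewhere on the aryl ring. Compound 3 differs from the others in more than one place, so the effects of its two fluorines and its ester side chain on the core remain unseparated.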